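From methyl to hydroxy in MDA-MB-231 cells

The compounds below may be only part of what the source reports. "The series", "measured", "known", "first", "only" and "open" are said of these compounds alone.

Compound 1 `CN(C)/C=C/C(=O)c1nn(-c2ccccc2)c(-c2ccccc2)c1C#N` gives 50400 nM
Compound 2 `Cc1nnc(-c2nn(-c3ccccc3)c(-c3ccccc3)c2C#N)c2cn(-c3ccccc3)nc12` gives > 100000 nM (a limit)

In a functional assay on MDA-MB-231 cells (Homo sapiens) for inhibition, read by sulforhodamine B assay, with a stated time of 48 h (on this read-out higher numbers stand for weaker inhibition of growth and lower numbers for stronger inhibition of growth), compound 2 gives > 100000 nM, which is a limit and not a number. Compound 3 `N#Cc1c(-c2nnc(O)c3nn(-c4ccccc4)cc23)nn(-c2ccccc2)c1-c1ccccc1` differs from compound 2 at one place, with hydroxy in place of methyl on an aromatic carbon. Among the compounds with values here, no step between measured compounds gauges this change, so any forecast is uncertain. Compound 1, at 50400 nM, shows that measurable inhibition of growth occurs in this series. The expected change is an at least 1.6-fold lower number from compound 2 to compound 3 (0.22 log units; that floor lies within the scatter), a modest one towards stronger inhibition. Compound 3 is estimated at 60000 nM, with an expected range of 20000 nM to 100000 nM.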

Compound 3, concentration for 50% growth inhibition: 6210 nM
Compound 3: middle estimate off by 9.7-fold (0.99 log units), on the high side, and the stated range ends above it.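

In this assay hydroxy in place of methyl on an aromatic carbon of the six-membered aromatic ring with 2 nitrogen gives an at least 16-fold lower number from compound 2 to compound 3 (1.20 log units; beyond the scatter) and brings the series into measurable range at this position, so what this carbon carries matters to the read-out. The earlier compounds shown here could not show this. The value of compound 2 is a limit and not a number, so the step gives only a floor: the limit of > 100000 nM in this assay, at which 1 of the 3 values shown sits.

Going by these compounds, it remains open whether an amine or a methoxy group on this carbon would behave like hydroxy. On these data alone, it is also open how far the effect of hydroxy carries over to other substituents on the shared core.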